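Sulfone and sulfide analogues tested for growth inhibition

This account rests on a few compounds, and the source may have more. Where it says the series, first, only, none or still open, it means among the compounds named here.

Compound 1 `O=C(/C(=C\c1ccc(Cl)cc1)S(=O)(=O)c1ccc(Br)cc1)c1ccc(Br)cc1`: 50000 nM
Compound 2 `COc1ccc(/C=C(\C(=O)c2ccc(Br)cc2)S(=O)(=O)c2ccc(Br)cc2)cc1`: 25000 nM
Compound 3 `COc1ccc(/C=C(/Sc2ccc(C)cc2)C(=O)c2ccc(Br)cc2)cc1`: 50000 nM

Of the compounds shown here, three have been measured in a functional assay on DU-145 cells (Homo sapiens) for inhibition, read by trypan blue exclusion, with a stated time of 96 h; a higher number here means a weaker inhibitor of growth, a lower number a stronger inhibitor of growth. Compound 2 gives 25000 nM in this assay, compound 1 gives 50000 nM, and compound 3 gives 50000 nM. Compound 1 and compound 3 stand level at the digits recorded, and compound 2 lies within the scatter of both, so no order among the three can be claimed.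

Compound 2 and compound 1 differ in one place: chloro in place of methoxy on an aromatic carbon. In this assay that change made a 2.0-fold higher number from compound 2 to compound 1 (0.30 log units; within the scatter).

Compound 4 `Cc1ccc(S/C(=C/c2ccc(Cl)cc2)C(=O)c2ccc(Br)cc2)cc1` has not yet been measured. It is related to compound 3 by the same kind of change, (chloro in place of methoxy on an aromatic carbon), in the same setting on the ring. The cores of compound 2 and compound 3, however, are not the same, and the difference between those two cores is not broken down here.

Going by the values given here, since the one earlier instance of this change, from compound 2 to compound 1, stayed within the scatter, compound 4 is expected to come out close to compound 3, with a step of about a 1.5-fold higher number from compound 3 to compound 4 (0.18 log units; within the scatter) in this assay, resting only on that one step and on the value of compound 3. The estimate for compound 4 in this assay is 75000 nM, with a range from 35000 nM to 160000 nM.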

Compound 4, concentration for 50% growth inhibition: 10000 nM
Compound 4: middle estimate off by 7.5-fold (0.88 log units), on the high side; the whole stated range lies above it.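

In this assay, putting chloro in place of methoxy gave a 5.0-fold lower number from compound 3 to compound 4 (0.70 log units; beyond the scatter) on the core of compound 3, and this step lies beyond the scatter. Set beside the earlier step, the result shows that the size of this change on one core did not carry over to the other in this series: the same change on two cores in this assay, a 2.0-fold higher number (0.30 log units; within the scatter) from compound 2 to compound 1 and a 5.0-fold lower number (0.70 log units; beyond the scatter) from compound 3 to compound 4, 10-fold (1.00 log units) apart, beyond the scatter of two such steps. Going by these compounds alone, this does not show why the two cores part, since they differ in more than one place and each core offers only a single step, and the earlier step, being within the scatter, cannot by itself establish a true loss on the core of compound 2; nor does it give any rule for a further core.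

The compounds shown leave open which of the differences between the two cores goes with the gap, and whether the gain seen on the core of compound 3 would hold in a second pair on that core. They also leave open how an amine, a hydroxyl or a carboxylic acid in place of the methoxy, on the same aromatic carbon, would behave on either core.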